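The source may report more compounds than this note shows. Statements on the series, on what has been measured and on what is new or still open speak of the compounds shown alone.

Of the compounds shown here, three built on one shared core have been tested in a functional assay on MCF7 cells (Homo sapiens) for cytotoxicity, read by MTT assay, with a stated time of 72 h; on this read-out lower numbers stand for stronger inhibition and higher numbers for weaker inhibition. Compound 1 `O=C(CSC(=S)N[C@H]1CCOC1=O)Nc1ccccc1` carries an unsubstituted phenyl ring on its amide; in this assay compound 1 gives > 128000 nM, which is a limit of the assay and not a number. Compound 2 `O=C(CSC(=S)N[C@H]1CCOC1=O)Nc1ccc(Cl)cc1Cl` carries two chlorines on that ring; in this assay compound 2 gives 29200 nM. Compound 3 `COc1ccc(NC(=O)CSC(=S)N[C@H]2CCOC2=O)cc1` carries a methoxy on the ring; in this assay compound 3 gives > 128000 nM, again a limit and not a number. Compound 3 thus sits at the limit of > 128000 nM in this assay, at which 2 of the 3 values shown sit. Within the data shown here, the only recorded single-change step, a step that the two limits leave unreadable from compound 1 to compound 3, is unreadable since both of its ends are limits.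

Compound 4 `CCOC(=O)c1ccc(NC(=O)CSC(=S)N[C@H]2CCOC2=O)cc1` differs from compound 3 by ethoxycarbonyl in place of methoxy on an aromatic carbon. Among the measured compounds shown here, no measured step speaks to this change; among the three compounds only compound 2, with 29200 nM, shows a number at all. No direction beyond the scatter can therefore be expected, and compound 4 is estimated at 100000 nM, within 30000 nM to 300000 nM, which amounts to an expected step of an at least 1.2-fold lower number from compound 3 to compound 4 (0.10 log units; that floor lies within the scatter).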

Compound 4, half-maximal inhibitory concentration: 60300 nM
Estimate against measurement, compound 4: 1.7-fold (0.22 log units) above, within the range that was stated.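

At this ring position, para to a large group, a substituent can now bring the result off the limit: in this assay, ethoxycarbonyl in place of methoxy gives an at least 2.1-fold lower number from compound 3 to compound 4 (0.32 log units; beyond the scatter). Among these compounds, measured against the unsubstituted ring, ethoxycarbonyl in place of hydrogen gives an at least 2.1-fold lower number from compound 1 to compound 4 (0.32 log units; beyond the scatter), which makes this the first single change on the ring with a readable direction, although the starting end of each step is only a limit and the full size stays unknown. The step from compound 1 to compound 3 still cannot be read, and limits remain common in this small set: the limit of > 128000 nM in this assay, at which 2 of the 4 values shown sit.

On these data alone, it remains open whether the ethoxycarbonyl group itself matters or whether other groups at this position would do the same. A carboxylic acid or an amine here would help to separate those two possibilities.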